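Dropping one chloro from the dichloro purine of compound 2

This account rests on a few compounds, and the source may have more. Where it says the series, first, only, none or still open, it means among the compounds named here.

Measured so far:
- compound 1, `ClCc1ccc(Cn2cnc3c(Cl)ncnc32)cc1`, with 3890 nM
- compound 2, `ClCc1ccccc1Cn1cnc2c(Cl)nc(Cl)nc21`, with 1380 nM

Both compounds were tested in a functional assay on MDA-MB-231 cells (Homo sapiens) for cytotoxicity, read by sulforhodamine B assay, with a stated time of 48 h; a higher number here means a weaker inhibitor of growth, a lower number a stronger inhibitor of growth. Compound 2 gives the lowest number of the two, and compound 1 gives a number that is higher by a margin beyond the usual scatter, so of these two, compound 2 is the stronger inhibitor of growth. The two compounds differ in more than one place, so nothing can be said about which difference carries that gap.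

Compound 3, `ClCc1ccccc1Cn1cnc2c(Cl)ncnc21`, differs from compound 2 in a single place: hydrogen in place of chloro on an aromatic carbon. The chloro that leaves sits on an aromatic carbon of a six-membered aromatic ring with two nitrogens, between two ring nitrogen atoms, and a hydrogen takes its place.

For the measured compounds named here, no measured pair shows what removing this chloro does, so the expected step rests on general experience only. The expectation is a modest move toward a higher number, of a size close to the edge of the scatter, as a 1.8-fold higher number from compound 2 to compound 3 (0.26 log units; within the scatter). Compound 3 is therefore expected to give about 2500 nM, within a range from 1000 nM to 6500 nM.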

Compound 3, concentration for total growth inhibition: 7410 nM
Compound 3: middle estimate off by 3.0-fold (0.47 log units), on the low side; measured number above the stated range.
By their numbers in this assay, from the lowest: compound 2; then compounds 1 and 3 (each within the scatter of the next).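

In this assay, putting hydrogen where the chloro stood, on the aromatic carbon between two ring nitrogen atoms, gives a 5.4-fold higher number from compound 2 to compound 3 (0.73 log units; beyond the scatter), a step beyond the scatter. This single atom therefore matters for growth inhibition in this series: the compound that keeps the chloro is the stronger inhibitor of the pair. Compounds 1 and 2 differ in more than one place and could not tie a gap to any one change, whereas this pair ties one to this position, although nothing measured here bears on the reason for the step.

On these data alone, only chloro and hydrogen are seen at this carbon, so it remains open whether the chloro itself is needed or whether another group, such as fluoro, methoxy or an amine, would serve as well or better. As far as these compounds go, it is also open whether adding a chloro at the same carbon of compound 1, which carries hydrogen there, would produce a step of similar size, so the effect cannot yet be extended beyond this one pair.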